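Thiourea aryl swap on the shared core: compound 3

This account rests on a few compounds, and the source may have more. Where it says the series, first, only, none or still open, it means among the compounds named here.

Measured compounds:
compound 1, `NC(=O)c1c(NC(=O)c2ccccc2Cl)sc2c1CCN(Cc1ccccc1)C2`, 12000 nM
compound 2, `NC(=O)c1c(NC(=O)c2ccccc2Cl)sc2c1CCN(C(=S)Nc1ccccc1C(F)(F)F)C2`, 10600 nM

In a functional assay on HL-60 cells (Homo sapiens) for antiproliferative activity, with a stated time of 24 h (a higher number here means a weaker inhibitor, a lower number a stronger inhibitor), compound 1 gives 12000 nM. Compound 2, which carries a thiourea on the ring nitrogen of the shared core, gives 10600 nM in this assay; the two numbers lie within the scatter of each other, so no order between compound 1 and compound 2 can be read from them.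

Compound 3, `COc1ccc(NC(=S)N2CCc3c(sc(NC(=O)c4ccccc4Cl)c3C(N)=O)C2)cc1`, differs from compound 2 by 4-methoxyphenyl in place of 2-(trifluoromethyl)phenyl on an amide-type nitrogen. Among the measured compounds shown here, no step between measured compounds touches this position, and the only comparison available, compound 1 against compound 2, shows that a large change at the ring nitrogen left the number where it was. On that basis the step from compound 2 to compound 3 is expected to be small, with no direction beyond the scatter, estimated at a 1.0-fold higher number from compound 2 to compound 3 (0.02 log units; within the scatter). Compound 3 is therefore expected to give about 11000 nM in this assay, with a range from 4000 nM to 30000 nM.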

Compound 3, half-maximal inhibitory concentration: 15700 nM
The estimate for compound 3 lay 1.4-fold (0.15 log units) below the measured number, within the range that was stated.
By their numbers in this assay, from the lowest: compounds 2, 1 and 3 (each within the scatter of the next).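

Among the compounds shown here, at the amide-type nitrogen of the thiourea, 4-methoxyphenyl in place of 2-(trifluoromethyl)phenyl gives in this assay a 1.5-fold higher number from compound 2 to compound 3 (0.17 log units; within the scatter) and so provides the first reading at this position: this aryl swap does not separate the two compounds. Against the benzyl group on the ring nitrogen of the shared core, the 4-methoxyphenyl thiourea gives a 1.3-fold higher number from compound 1 to compound 3 (0.12 log units; within the scatter) and so adds a second thiourea that cannot be told apart from compound 1. No measurement at hand offers an explanation for these small steps.

Two aryl groups are too few to show whether this position tolerates all substitution or whether these two groups merely happen to read alike. Going by these compounds, a plain phenyl, a phenyl carrying a carboxylic acid or an amine, or a longer alkyl chain in place of the aryl group remains open at this nitrogen.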